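The source may hold more compounds than are shown below. What is called first, only, known or untested is meant among the compounds shown, and "the series" means these compounds.

Series notes. Compound 1 `Cc1cccc(-c2noc([C@H](C)NC(=O)c3cc(C(F)(F)F)nn3C)n2)n1`, compound 2 `Cc1cc(-c2noc([C@H](C)NC(=O)c3cc(C(F)(F)F)nn3C)n2)ccn1` and compound 3 `C[C@H](NC(=O)c1cc(C(F)(F)F)nn1C)c1nc(-c2ccncc2)no1` share one core and differ only in the six-membered ring attached to it. In an assay on T-REx-293 cells for inhibition of potassium channel subfamily T member 1 (Homo sapiens), read by patch clamp (a higher number here means a weaker inhibitor, a lower number a stronger inhibitor), compound 1 gives > 30000 nM, a limit of the assay rather than a number (the limit of > 30000 nM in this assay, at which 1 of the 3 values shown sits). Compound 2 gives 165 nM and compound 3 gives 5250 nM in this assay; compound 3 thus holds the highest measured number, compound 2 nearest (a 32-fold higher number from compound 2 to compound 3 (1.50 log units; beyond the scatter)). Compound 4 `Cc1cc(-c2noc([C@H](C)NC(=O)c3cc(C(F)(F)F)nn3C)n2)ncn1` differs from compound 3 by 6-methylpyrimidin-4-yl in place of pyridin-4-yl on an aromatic carbon. The step of a 32-fold higher number from compound 2 to compound 3 (1.50 log units; beyond the scatter), loss of the methyl, bears most directly, and an at least 5.7-fold lower number from compound 1 to compound 3 (0.75 log units; beyond the scatter) shows the ring itself also matters. A step of about a 12-fold lower number from compound 3 to compound 4 (1.07 log units; beyond the scatter) toward a lower number is expected. Compound 4 is estimated at 450 nM, within 100 nM to 2500 nM.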

Compound 4, half-maximal inhibitory concentration: 1410 nM
Beside the measured number, compound 4's estimate is 3.1-fold (0.50 log units) below it; measured number inside the range.
By their numbers in this assay, from the lowest: compound 2; then compound 4; then compound 3. At a limit, above all of these: compound 1.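

In this assay, 6-methylpyrimidin-4-yl on this aromatic carbon improves on pyridin-4-yl (a 3.7-fold lower number from compound 3 to compound 4 (0.57 log units; beyond the scatter)), so a second ring nitrogen together with a methyl is tolerated here. It still falls short of 2-methylpyridin-4-yl (an 8.5-fold higher number from compound 2 to compound 4 (0.93 log units; beyond the scatter)) but stays well ahead of 6-methylpyridin-2-yl (an at least 21-fold lower number from compound 1 to compound 4 (1.32 log units; beyond the scatter)). That last step rests on a limit held by compound 1: the limit of > 30000 nM in this assay, at which 1 of the 4 values shown sits. Open, from the compounds shown here alone, is how pyrimidin-4-yl without the methyl would read, and whether an amine or a methoxy group in place of that methyl would approach compound 2.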